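The compounds below may be only part of what the source reports. "The series", "measured", "known", "first", "only" and "open" are said of these compounds alone.

Three compounds share one core and differ only in the aromatic ring that sits on the carbonyl carbon of an amide. Compound 1 `O=C(Nc1ccc(Sc2nc3ccccc3s2)cc1)c1cc(Br)cc(Br)c1` carries a 3,5-dibromophenyl there, compound 2 `COc1c(Br)cccc1C(=O)Nc1ccc(Sc2nc3ccccc3s2)cc1` a ring bearing one bromine and one methoxy group, and compound 3 `O=C(Nc1ccc(Sc2nc3ccccc3s2)cc1)c1ccccc1O` a 2-hydroxyphenyl. In an assay for inhibition of HSP60/HSP10 (Homo sapiens), with a stated time of 60 min (a lower number here means a stronger inhibitor, a higher number a weaker inhibitor), compound 1 gives > 100000 nM, which is a limit of the measurement rather than a number. Compound 2 likewise reaches only a limit, > 100000 nM. Compound 3 stands at a limit as well, > 100000 nM. None of the three steps between these compounds can be read because every value sits at the limit of > 100000 nM in this assay, at which 3 of the 3 values shown sit: the steps a step that the two limits leave unreadable from compound 1 to compound 2, a step that the two limits leave unreadable from compound 1 to compound 3 and a step that the two limits leave unreadable from compound 2 to compound 3 are all of unknown size.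

Compound 4 `O=C(Nc1ccc(Sc2nc3ccccc3s2)cc1)c1cc(Br)cc(Br)c1O` is the next compound: 3,5-dibromo-2-hydroxyphenyl in place of 2-hydroxyphenyl on a carbonyl carbon. Within the data shown here, this ring joins the two bromines of compound 1 with the hydroxyl of compound 3, and both of those compounds gave only limits, so no measured step gives a direction for the change. The step from compound 3 to compound 4 is therefore expected to be small, about a step that the limit leaves unreadable from compound 3 to compound 4. Compound 4 is expected to give 150000 nM in this assay, with a likely range from 30000 nM to 1000000 nM, and most probably only a limit again.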

Compound 4, half-maximal inhibitory concentration: 4700 nM
Compound 4: middle estimate off by 32-fold (1.50 log units), on the high side; measured number outside the range, below it.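

On the carbonyl carbon of the amide in this assay, putting two bromines onto the 2-hydroxyphenyl ring gives an at least 21-fold lower number from compound 3 to compound 4 (1.32 log units; beyond the scatter), and hydroxy in place of hydrogen on an aromatic carbon of the 3,5-dibromophenyl ring gives an at least 21-fold lower number from compound 1 to compound 4 (1.32 log units; beyond the scatter). The hydroxyl and the two bromines thus produce a measurable number only when they stand together on one ring, while neither the 2-hydroxyphenyl ring alone nor the 3,5-dibromophenyl ring alone does so, and the ring with one bromine and one methoxy group also falls short, with an at least 21-fold lower number from compound 2 to compound 4 (1.32 log units; beyond the scatter). How much the weaker compounds differ among themselves stays unknown, and the steps among them cannot be read: the limit of > 100000 nM in this assay, at which 3 of the 4 values shown sit.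

The compounds shown leave open whether a single bromine together with the hydroxyl would be enough, or whether both bromines are needed. They also leave open whether chlorine could stand in for bromine, and whether an amine or a carboxylic acid could take the place of the hydroxyl on this ring and keep a measurable number.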